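Benzylic bromide in place of benzylic alcohol

The source may report more compounds than this note shows. Statements on the series, on what has been measured and on what is new or still open speak of the compounds shown alone.

Compound 3 `CCc1cccc2c(OC)c(-c3occ(C)c3CO)ccc12` is one of the alcohol members of the series. In a functional assay on MDA-MB-231 cells (Homo sapiens) for cytotoxicity, read by MTT assay, with a stated time of 72 h (on this read-out lower numbers stand for an effect already at smaller amounts and higher numbers for an effect only at larger amounts of compound), compound 3 gives only a limit, > 10 ug/mL, and not a number. Compound 2 `CCc1cccc2c(OC)c(-c3occ(C)c3C(=O)NC)ccc12` likewise gives only a limit in this assay, > 10 ug/mL. Among the measured compounds shown here, compound 1 `CCc1cccc2c(OC)c(-c3occ(C)c3C(=O)OC)ccc12` is the sole member with a number, 1.3 ug/mL, so that the limit of > 10 ug/mL in this assay, at which 2 of the 3 values shown sit, holds two of the three values shown. Compound 4 `CCc1cccc2c(OC)c(-c3occ(C)c3CBr)ccc12` differs from compound 3 by bromo in place of hydroxy on a saturated chain carbon bound to an aromatic carbon. For the measured compounds named here, no measured step changes a group on this saturated chain carbon; the steps that reach compound 3 are an at least 7.6-fold higher number from compound 1 to compound 3 (0.88 log units; beyond the scatter) and a step that the two limits leave unreadable from compound 2 to compound 3, and the second of them cannot be read. Going by the values given here, the hydroxy-to-bromo exchange therefore has no precedent, and the step of an at least 1.6-fold lower number from compound 3 to compound 4 (0.22 log units; that floor lies within the scatter) is an expectation resting only on the starting point being a limit. Compound 4 is estimated at 6 ug/mL, between 1.5 ug/mL and 25 ug/mL, with a fair chance that this assay again reports only a limit.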

Compound 4, concentration for half-maximal effect: 4.6 ug/mL
For compound 4 the middle estimate is 1.3-fold (0.12 log units) above the measured one; low and high end bracket the measured number.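

Among the compounds shown here, this is the first measured change on the saturated chain carbon bound to an aromatic carbon, and in this assay it returns a number: bromo in place of hydroxy gives an at least 2.1-fold lower number from compound 3 to compound 4 (0.33 log units; beyond the scatter) on this exchange alone. Bromomethyl in place of methylcarbamoyl gives an at least 2.1-fold lower number from compound 2 to compound 4 (0.33 log units; beyond the scatter) at the same aromatic carbon, so methoxycarbonyl is no longer the only group there to give a number. Methoxycarbonyl is not matched, however: bromomethyl in its place gives a 3.5-fold higher number from compound 1 to compound 4 (0.55 log units; beyond the scatter) in this series.

Compound 2 and compound 3 remain limits and not numbers, so the full size of their steps to compound 4 stays unread: the limit of > 10 ug/mL in this assay, at which 2 of the 4 values shown sit. Going by these compounds, whether chloromethyl, aminomethyl or a carboxylic acid at this aromatic carbon would sit nearer compound 1 or compound 4 also remains open.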